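A few compounds are considered here, and "the series" means these few. Any claim that something is new, unique, unknown or untested is made for them only; others in the source may bear on it.

Measured compounds in the series:

Compound 1, `COc1cc(Nc2nc3ccccc3nc2S(=O)(=O)c2ccc(C)cc2)cc(OC)c1`, gives 2940 nM in a functional assay on PC-3 cells (Homo sapiens) for cytotoxicity, read by MTT assay, with a stated time of 72 h; a higher number here means a weaker inhibitor, a lower number a stronger inhibitor.
Compound 2, `COc1cc(Nc2nc3ccccc3nc2S(=O)(=O)c2ccc(C)cc2)cc(OC)c1OC`, gives 4850 nM in this assay.
Compound 3, `Cc1ccc(S(=O)(=O)c2nc3ccccc3nc2Nc2ccc(N)cc2)cc1`, gives 5000 nM in this assay.

Compound 2 sits among numbers that are all close together: its value and that of compound 3 lie within the scatter of each other, and its separation from compound 1 is a 1.6-fold higher number from compound 1 to compound 2 (0.22 log units; within the scatter), also within the scatter. The three numbers therefore give no resolved order.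

The next compound, compound 4, `COc1ccc(S(=O)(=O)c2nc3ccccc3nc2Nc2cc(OC)c(OC)c(OC)c2)cc1`, differs from compound 2 by methoxy in place of methyl on an aromatic carbon. Neither measured step bears directly on this position. The step of a 1.6-fold higher number from compound 1 to compound 2 (0.22 log units; within the scatter) and the step of a 1.7-fold higher number from compound 1 to compound 3 (0.23 log units; within the scatter) both change the group on the nitrogen of the shared core, leaving the sulfonyl side untouched, and both stayed within the scatter. Among the compounds with values here, the sulfonyl-side change in compound 4 thus has no measured precedent in this set, and the closest information is that substituent changes elsewhere on the core moved this assay little.

On that basis no step beyond the scatter is expected for compound 4, in either direction, with the estimated step being a 1.0-fold lower number from compound 2 to compound 4 (0.00 log units; within the scatter). Compound 4 is estimated at 4800 nM in this assay, with a range from 1900 nM to 12000 nM.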

Compound 4, half-maximal inhibitory concentration: 7850 nM
Beside the measured number, compound 4's estimate is 1.6-fold (0.21 log units) below it, within the range that was stated.
By their numbers in this assay, from the lowest: compounds 1, 2, 3 and 4 (each within the scatter of the next, the first and the last beyond it).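

The sulfonyl side of the shared core now has its first reading: in this assay, 4-methoxyphenyl in place of 4-methylphenyl on the sulfonyl gives a 1.6-fold higher number from compound 2 to compound 4 (0.21 log units; within the scatter) and so leaves no resolved change at this position. The exchange of methyl for methoxy on this aromatic carbon, para to a large group, therefore joins the two changes on the nitrogen side of the core, a 1.6-fold higher number from compound 1 to compound 2 (0.22 log units; within the scatter) and a 1.7-fold higher number from compound 1 to compound 3 (0.23 log units; within the scatter), as a step that stays within the scatter, so none of the single changes shown so far separates a pair of compounds in this assay. No measurement at hand offers an explanation for the step from methyl to methoxy.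

Still open, on these data alone, is whether a group of another kind on this same aromatic carbon, such as an amine, a carboxylic acid or a longer chain like butoxy, would move the number beyond the scatter. Also open, as far as these compounds go, is whether the methyl to methoxy exchange reads the same when the nitrogen carries 3,5-dimethoxyphenyl or 4-aminophenyl rather than the group found in compound 2.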